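A few compounds are considered here, and "the series" means these few. Any claim that something is new, unique, unknown or untested is made for them only; others in the source may bear on it.

Measured so far: compound 1, `COc1cc(C2=NN(C(C)=O)C(c3cccc(OC)c3OC)O2)cc(OC)c1OC`, 58.2%; compound 2, `COc1cc(C2=NN(C(C)=O)C(c3ccc(C(F)(F)F)cc3)O2)cc(OC)c1OC`, -0.7%.

In a functional assay on PC-3 cells (Homo sapiens) for antiproliferative activity, read by MTT assay, tested at 5 uM (a higher number here means a stronger effect of the compound at the concentration tested, a lower number a weaker effect), compound 1 gives 58.2%, while compound 2 gives -0.7%. Going by the values given here, compound 2 thus stands lowest of the two numbers, with compound 1 as its only neighbour. Among the compounds with values here, the one step known so far is a number 58.9 percentage points lower from compound 1 to compound 2 (beyond the scatter). Compound 3, `COc1cc(C2=NN(C(C)=O)C(c3ccccc3F)O2)cc(OC)c1OC`, differs from compound 2 in one place: 2-fluorophenyl in place of 4-(trifluoromethyl)phenyl on a saturated ring carbon. Within the data shown here, no measured step exchanges one fluorine-bearing aryl group for another, so the only guide is that single large step, which shows that the group on this saturated ring carbon can shift this assay across most of its range. A return to the level of compound 1 cannot be assumed, but an upward step beyond the scatter is estimated: a number 15.7 percentage points higher from compound 2 to compound 3 (beyond the scatter). Compound 3 is therefore expected to give 15%, within a range from -10% to 45%.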

Compound 3, a percentage reported as inhibition, at one concentration (the size of the read-out at that concentration, not a potency): 31.6%
Beside the measured number, compound 3's estimate is 16.6 percentage points below it; low and high end bracket the measured number.
By their numbers in this assay, from the lowest: compound 2; then compound 3; then compound 1.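

In this assay, the change to 2-fluorophenyl gives a number 32.3 percentage points higher from compound 2 to compound 3 (beyond the scatter) and, set against 2,3-dimethoxyphenyl, a number 26.6 percentage points lower from compound 1 to compound 3 (beyond the scatter) so the group on this saturated ring carbon now sets three separate levels rather than two. A fluorine-bearing phenyl group at this place therefore does not by itself abolish the effect, and yet 2-fluorophenyl does not reach the level of 2,3-dimethoxyphenyl.

No evidence at hand accounts for these differences. The two fluorine-bearing groups differ both in the substituent and in where it sits on the phenyl ring, so the compounds shown cannot separate these two changes, and they leave open how a phenyl group carrying a hydroxyl or an amine would behave on this carbon.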